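This account rests on a few compounds, and the source may have more. Where it says the series, first, only, none or still open, it means among the compounds named here.

Compound 1 `CC(C)C(=O)OC[C@H]1C[C@@H](Cl)C[C@@H](c2ccc3ccccc3c2)O1`: 44.4%
Compound 2 `CC(C)C(=O)OC[C@H]1C[C@@H](Cl)C[C@@H](c2cccc3ccccc23)O1`: 38.4%
Compound 3 `OC[C@H]1C[C@@H](Cl)C[C@@H](c2ccc3ccccc3c2)O1`: 46.6%

All three were tested in a functional assay on the whole organism (Abdomen, strain Swiss albino) for inhibition, with Mus musculus as the target, in the writhing test, with a stated time of 30 min, at a dose of 30 mg/kg by the oral route; a higher number here means more inhibition at the dose given (going by the name of the read-out), a lower number less inhibition. Compound 3 differs from compound 1 by hydrogen in place of isopropylcarbonyl on an oxygen on a saturated carbon, and this change gave a number 2.2 percentage points higher from compound 1 to compound 3 (within the scatter). Compound 2 has the same atoms as compound 1 joined differently; the difference between the two cores is not broken down here. The three values lie within the usual scatter of one another.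

Compound 4 `OC[C@H]1C[C@@H](Cl)C[C@@H](c2cccc3ccccc23)O1` has not yet been measured. It differs from compound 2 by hydrogen in place of isopropylcarbonyl on an oxygen on a saturated carbon, the same change that turned compound 1 into compound 3, made at the same place. Compound 4 is expected to change little from compound 2, a number 2.2 percentage points higher from compound 2 to compound 4 (within the scatter), because the same change earlier gave a number 2.2 percentage points higher from compound 1 to compound 3 (within the scatter). Compound 4 is therefore estimated to give 40.6% in this assay, with a likely range from 30% to 51%.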

Compound 4, a percentage reported as inhibition, in the whole organism at one dose (the size of the read-out at that dose, not a potency): 87.5%
For compound 4 the middle estimate is 46.9 percentage points below the measured one, and the stated range ends below it.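

Replacing isopropylcarbonyl with hydrogen on the oxygen gives a number 49.1 percentage points higher from compound 2 to compound 4 (beyond the scatter) in this assay. The size of this step did not carry over from one core to the other: the same change on two cores in this assay, a number 2.2 percentage points higher (within the scatter) from compound 1 to compound 3 and a number 49.1 percentage points higher (beyond the scatter) from compound 2 to compound 4, 46.9 percentage points apart, beyond the scatter of two such steps. This shows that, in these two pairs, the result of the change depends on the core, but two pairs give no general rule for other cores and do not explain the gap.

The compounds shown carry only hydrogen or isopropylcarbonyl on this oxygen, so the effect of an acetyl group or a longer acyl chain remains open. On these data alone, whether an amine in place of the hydroxy group would keep the value of compound 4, 87.5%, is also open.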